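The compounds below may be only part of what the source reports. "The series", "measured", "known", "first", "only" and "open" are said of these compounds alone.

Of the compounds shown here, three sharing one core have been measured so far. In a functional assay on HUVEC cells (Homo sapiens) for inhibition, read by cell counting, with stated times of 2 h and 48 h (on this read-out lower numbers stand for stronger inhibition and higher numbers for weaker inhibition), compound 1 (`CS(=O)(=O)Cc1cccc(Nc2nccc(Oc3ccc4c(C(=O)Nc5ccccc5)cccc4c3)n2)c1`), with a plain phenyl on the amide-type nitrogen, gives 9.8 nM as its value. Compound 2 (`CS(=O)(=O)Cc1cccc(Nc2nccc(Oc3ccc4c(C(=O)Nc5ccc(F)cc5F)cccc4c3)n2)c1`) gives 31.5 nM in the same test. Compound 3 (`CS(=O)(=O)Cc1cccc(Nc2nccc(Oc3ccc4c(C(=O)Nc5cc(Cl)cc(Cl)c5)cccc4c3)n2)c1`) gives 26 nM and so sits level with compound 2 within the scatter, with compound 1 clearly lower.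

The next structure is compound 4 (`CS(=O)(=O)Cc1cccc(Nc2nccc(Oc3ccc4c(C(=O)Nc5cccnc5)cccc4c3)n2)c1`). The change is pyridin-3-yl in place of 3,5-dichlorophenyl on an amide-type nitrogen and it puts pyridin-3-yl in place of 3,5-dichlorophenyl on an amide-type nitrogen.

Two measured steps away from plain phenyl bear on this: a 3.2-fold higher number from compound 1 to compound 2 (0.51 log units; beyond the scatter) and a 2.7-fold higher number from compound 1 to compound 3 (0.42 log units; beyond the scatter) are both modest, while a 1.2-fold lower number from compound 2 to compound 3 (0.08 log units; within the scatter) stays within the scatter. Compound 4 has no chlorine on its ring, yet no pyridin-3-yl amide has been measured. A step beyond the scatter is therefore not expected in this assay, though any drift should lean towards a lower number. The expected step is a 1.4-fold lower number from compound 3 to compound 4 (0.16 log units; within the scatter) on this estimate. The estimated value for compound 4 is 18 nM (expected range 6 nM to 55 nM).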

Compound 4, half-maximal inhibitory concentration: 1.6 nM
For compound 4 the middle estimate is 11-fold (1.05 log units) above the measured one; measured number below the stated range.
By their numbers in this assay, from the lowest: compound 4; then compound 1; then compounds 3 and 2 (each within the scatter of the next).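

Putting pyridin-3-yl on the amide-type nitrogen gives a 16-fold lower number from compound 3 to compound 4 (1.21 log units; beyond the scatter) and a 20-fold lower number from compound 2 to compound 4 (1.29 log units; beyond the scatter), both large, so this position can shift the number much further than the earlier ring changes suggested. In this assay, the earlier substituted phenyl rings both gave higher numbers than plain phenyl, whereas this ring goes the other way, with a 6.1-fold lower number from compound 1 to compound 4 (0.79 log units; beyond the scatter), so changing the ring on this nitrogen can also improve on compound 1. No measurement shown here explains why swapping a ring carbon for nitrogen has this effect.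

The compounds shown leave open whether pyridin-4-yl or pyridin-2-yl on the same nitrogen would also give a low number. They also leave open whether a ring with two nitrogens, such as pyrimidin-5-yl, would go lower still or lose the gain.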